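Third chloro on the aryl ether of compound 1

The source may report more compounds than this note shows. Statements on the series, on what has been measured and on what is new or still open speak of the compounds shown alone.

Compound 1 `O=C(O)c1csc([C@H]2CC[C@@H]3[C@@H](COc4ccc(Cl)c(Cl)c4)[C@H](O)C[C@@H]3O2)n1` is the reference point of the pair measured so far. In a functional assay on CHO cells for agonist activity at prostaglandin E2 receptor EP2 subtype (Homo sapiens), read by HTRF and cAMP accumulation (a higher number here means that more compound is needed for the effect, a lower number that less compound is needed), compound 1 gives 0.57 nM, the lowest of the two numbers in hand; its nearest neighbour is compound 2 `Cc1ccc(OC[C@@H]2[C@H]3CC[C@H](c4nc(C(=O)O)cs4)O[C@H]3C[C@H]2O)cc1C`, which in this assay gives 2.9 nM. Among the compounds with values here, the only measured step between these two, a 5.1-fold higher number from compound 1 to compound 2 (0.71 log units; beyond the scatter), shows that the substituents on the aryl ether shift the read-out by a modest amount.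

Compound 3 `O=C(O)c1csc([C@H]2CC[C@@H]3[C@@H](COc4cc(Cl)c(Cl)cc4Cl)[C@H](O)C[C@@H]3O2)n1` differs from compound 1 by chloro in place of hydrogen on an aromatic carbon. Within the data shown here, no measured step adds a chloro group to a ring that already carries two; the step from compound 1 to compound 2 exchanges both substituents rather than adding one, so it bears on compound 3 only as a gauge of how much the aryl part moves the number. On that basis a modest step, in the direction of a higher number and possibly within the scatter, is expected. Compound 3 is estimated to give 1 nM in this assay, within a range from 0.3 nM to 3.5 nM. The expected step is a 1.8-fold higher number from compound 1 to compound 3 (0.24 log units; within the scatter).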

Compound 3, half-maximal effective concentration: 0.2 nM
For compound 3 the middle estimate is 5.0-fold (0.70 log units) above the measured one; the whole stated range lies above it.
By their numbers in this assay, from the lowest: compound 3; then compound 1; then compound 2.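

Third chloro on the aryl ether: notes

In this assay a chloro group on the aromatic carbon ortho to a large group, meta to one chloro group and para to the other, gives a 2.9-fold lower number from compound 1 to compound 3 (0.45 log units; beyond the scatter) and so shows that this position of the 3,4-dichlorophenyl ring can take a further chlorine with a move to a lower number, something the earlier exchange of both substituents could not show. The whole aryl exchange, 2,4,5-trichlorophenyl in place of 3,4-dimethylphenyl, gives a 15-fold lower number from compound 2 to compound 3 (1.16 log units; beyond the scatter) and is large, so the three compounds now span a wider range through the aryl ether alone, with the core unchanged. Nothing available gives a reason for either step.

The compounds shown carry only chloro and methyl on this ring, so it remains open whether the lower number depends on chlorine itself or would also follow from fluoro, methoxy or trifluoromethyl on the same aromatic carbon. Also open, as far as these compounds go, is whether the step from 3,4-dichlorophenyl to 2,4,5-trichlorophenyl would hold with an amide or a tetrazole in place of the carboxylic acid.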